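A few compounds are considered here, and "the series" means these few. Any claim that something is new, unique, unknown or untested is made for them only; others in the source may bear on it.

In a functional assay on heart right ventricle (Rattus norvegicus, strain WKY), tested at 1 uM (a higher number here means a weaker effect of the compound at the concentration tested, a lower number a stronger effect), compound 1 `CCCCO[C@H](c1ccc(O)c(O)c1)[C@H](CC#Cc1ccc(O)c(O)c1)O[C@@H]1O[C@H](CO)[C@@H](O)[C@H](O)[C@H]1O` gives 95.8%, and compound 2 `CCCCO[C@@H](c1ccc(O)c(O)c1)[C@H](CC#Cc1ccc(O)c(O)c1)O[C@@H]1O[C@H](CO)[C@@H](O)[C@H](O)[C@H]1O` gives 100%; the two compounds differ only in configuration as drawn (the fact that compounds 1 and 2 differ only in the configuration as drawn), and the step of a number 4.2 percentage points higher from compound 1 to compound 2 (within the scatter) stays within the scatter. Compound 3 `OC[C@H]1O[C@@H](O[C@@H](CC#Cc2ccc(O)c(O)c2)[C@H](O)c2ccc(O)c(O)c2)[C@H](O)[C@@H](O)[C@@H]1O` gives 84.8%, the lowest of the three numbers, and the step of a number 11 percentage points lower from compound 1 to compound 3 (beyond the scatter) is modest. Compound 4 `OC[C@H]1O[C@@H](O[C@@H](CC#Cc2ccc(O)cc2)[C@H](O)c2ccc(O)c(O)c2)[C@H](O)[C@@H](O)[C@@H]1O` differs from compound 3 in one place: hydrogen in place of hydroxy on an aromatic carbon. Among the compounds with values here, no measured step touches a group on an aromatic ring, so the two measured steps bear on this change only loosely, and the only one beyond the scatter was modest. Compound 4 is therefore expected at 88%, with a range from 72% to 100%. That estimate means a number 3.2 percentage points higher from compound 3 to compound 4 (within the scatter), a step expected to remain within the scatter.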

Compound 4, a percentage reported as activity, at one concentration (the size of the read-out at that concentration, not a potency): 98.4%
Compound 4: the middle estimate sits 10.4 percentage points below what was measured; measured number inside the range.
By their numbers in this assay, from the lowest: compound 3; then compounds 1, 4 and 2 (each within the scatter of the next).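

Taking the hydroxy off the 3,4-dihydroxyphenyl group, which leaves 4-hydroxyphenyl, is the first change on an aromatic ring here, and in this assay it gives a number 13.6 percentage points higher from compound 3 to compound 4 (beyond the scatter) and so a weaker effect at the concentration tested. The lowest number, held by compound 3, is thus lost through this ring change as well as through butyl on the chain oxygen. Nothing known about these compounds accounts for this step.

From the compounds shown here alone, only hydrogen has replaced this hydroxy, so what a methoxy group or a fluorine atom would do at this position remains open. Equally open, going by these compounds, is whether the hydroxy groups of the other aromatic ring matter as this one does.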